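The source may report more compounds than this note shows. Statements on the series, on what has been measured and on what is new or still open speak of the compounds shown alone.

Compound 1 `O=C1c2ccccc2S(=O)(=O)N1CCCCCCN1CCN(c2ccccc2F)CC1` and compound 2 `O=C1c2ccccc2S(=O)(=O)N1CCCCCCN1CCN(c2cccc3cccnc23)CC1` share one core and differ only in the aryl group on an amine nitrogen in a ring. In an ADME assay on HEK293 cells for displacement of a labelled ligand from 5-hydroxytryptamine receptor 6 (Homo sapiens), read by radioligand binding, with a stated time of 1 h (a lower number here means a stronger inhibitor, a higher number a weaker inhibitor), compound 1 gives 1620 nM. In this assay, among the measured compounds shown here, compound 2 gives 1720 nM; of the two numbers so far this is nominally the higher one, yet the step of a 1.1-fold higher number from compound 1 to compound 2 (0.03 log units; within the scatter) lies within the scatter, so the two values are treated as equal.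

Compound 3 `O=C1c2ccccc2S(=O)(=O)N1CCCCCCN1CCN(c2ncccn2)CC1` is the next member: pyrimidin-2-yl in place of quinolin-8-yl on an amine nitrogen in a ring. For the measured compounds named here, the only measured step that bears on this position is a 1.1-fold higher number from compound 1 to compound 2 (0.03 log units; within the scatter), where exchanging the aryl group on the same ring nitrogen left the number essentially unchanged. On that basis no step beyond the scatter is expected in this assay in either direction; with a single comparison behind it, the range is kept wide. The expected step is a 1.0-fold lower number from compound 2 to compound 3 (0.01 log units; within the scatter). Compound 3 is therefore estimated at 1700 nM in this assay, with a range from 600 nM to 5000 nM.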

Compound 3, inhibition constant: 104 nM
For compound 3 the middle estimate is 16-fold (1.21 log units) above the measured one; measured number below the stated range.
By their numbers in this assay, from the lowest: compound 3; then compounds 1 and 2 (each within the scatter of the next).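

At this position, on an amine nitrogen in a ring, the aryl group does matter in this assay: pyrimidin-2-yl gives a 17-fold lower number from compound 2 to compound 3 (1.22 log units; beyond the scatter) and a 16-fold lower number from compound 1 to compound 3 (1.19 log units; beyond the scatter), whereas the earlier exchange gave only a 1.1-fold higher number from compound 1 to compound 2 (0.03 log units; within the scatter), which lies within the scatter. The flat result from the first pair therefore does not hold for the position as a whole, and compound 3 is the only one of the three that stands apart, with both of its steps beyond the scatter. The change to compound 3 replaces a two-ring group of 10 heavy atoms with a single six-membered aromatic ring with 2 hetero atoms and 6 heavy atoms, but no measurement here explains the drop in the number.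

The three compounds do not separate ring size from ring nitrogen count, so pyridin-2-yl and unsubstituted phenyl on the same nitrogen would be the informative neighbours of pyrimidin-2-yl. As far as these compounds go, whether the step from pyrimidin-2-yl persists with a shorter chain in place of the six-carbon chain also remains open.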